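Fluorophenyl in place of trifluoromethylphenyl on the urea analogue

The compounds below may be only part of what the source reports. "The series", "measured", "known", "first", "only" and "open" are said of these compounds alone.

Among the compounds with values here, in a functional assay on SW-620 cells (Homo sapiens) for inhibition, read by MTT assay, with a stated time of 48 h (on this read-out higher numbers stand for weaker inhibition and lower numbers for stronger inhibition), compound 3 `Cc1ccc(NC(=O)NC(=O)c2ccc(OCc3ccc(C(F)(F)F)cc3)cc2)cc1-c1nc2ccccc2[nH]1` gives 15300 nM, the second highest of the three numbers measured so far. Within the data shown here, compound 1 `Cc1ccc(NC(=S)NC(=O)c2ccc(OCc3cccc(C(F)(F)F)c3)cc2)cc1-c1nc2ccccc2[nH]1` gives 15400 nM in this assay, within the scatter of compound 3, while compound 2 `Cc1ccc(NC(=S)NC(=O)c2ccc(OCc3ccccc3F)cc2)cc1-c1nc2ccccc2[nH]1` gives 6440 nM in this assay, the only number beyond the scatter from compound 3. Compound 4 `Cc1ccc(NC(=O)NC(=O)c2ccc(OCc3cccc(F)c3)cc2)cc1-c1nc2ccccc2[nH]1` is not yet measured; it differs from compound 3 by 3-fluorophenyl in place of 4-(trifluoromethyl)phenyl on a saturated chain carbon bound to an oxygen on an aromatic ring. Among the measured compounds shown here, the one step that bears on this change is a 2.4-fold lower number from compound 1 to compound 2 (0.38 log units; beyond the scatter), a change of the same kind on a related pair. On that single precedent a modest move toward a lower number, a 1.8-fold lower number from compound 3 to compound 4 (0.26 log units; within the scatter), is expected. Compound 4 is therefore estimated at 8500 nM, with a range from 3500 nM to 20000 nM.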

Compound 4, half-maximal inhibitory concentration: 39600 nM
Beside the measured number, compound 4's estimate is 4.7-fold (0.67 log units) below it; measured number outside the range, above it.
By their numbers in this assay, from the lowest: compound 2; then compounds 3 and 1 (each within the scatter of the next); then compound 4.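

In this assay, 3-fluorophenyl in place of 4-(trifluoromethyl)phenyl gives a 2.6-fold higher number from compound 3 to compound 4 (0.41 log units; beyond the scatter), whereas the earlier step of the same kind gave a 2.4-fold lower number from compound 1 to compound 2 (0.38 log units; beyond the scatter). A fluorophenyl for a trifluoromethylphenyl at this place therefore does not shift the number in one fixed direction across these two pairs. Nothing available here accounts for the opposite directions.

The two pairs differ both in the substituent positions on the ring and in the urea or thiourea link, so these compounds leave open which of the two decides the direction. Going by these compounds, how an unsubstituted phenyl or a 4-chlorophenyl would read at this place also stays open.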